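This account rests on a few compounds, and the source may have more. Where it says the series, first, only, none or still open, it means among the compounds named here.

Measured in a functional assay on HepG2 cells (Homo sapiens) for inhibition, read by MTT assay, with a stated time of 24 h, tested at 10 uM; on this read-out higher numbers stand for more inhibition of growth at the one concentration tested and lower numbers for less inhibition of growth:
compound 1 `CS(=O)(=O)c1ccc(-c2cnc3[nH]cc(-c4nnc(-c5ccccc5)o4)c(=O)c3c2)cc1` gives 6.98%
compound 2 `CS(=O)(=O)c1ccc(-c2cnc3[nH]cc(-c4nnc(-c5ccc(Cl)cc5)o4)c(=O)c3c2)cc1` gives 11.6%
compound 3 `N#Cc1ccc(-c2cnc3[nH]cc(-c4nnc(-c5ccc(Cl)cc5)o4)c(=O)c3c2)cc1` gives 12.7%

Compound 3 stands at the top of these three numbers, yet the gap to compound 2 and the gap to compound 1 both lie within the scatter, so the three compounds do not separate on this read-out. The two steps among them confirm this: a number 4.6 percentage points higher from compound 1 to compound 2 (within the scatter) and a number 1.1 percentage points higher from compound 2 to compound 3 (within the scatter). Neither exchange on the shared core moved the read-out beyond the noise.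

Compound 4 `O=c1c(-c2nnc(-c3ccc(Cl)cc3)o2)c[nH]c2ncc(-c3ccccc3)cc12` is not yet measured. Its difference from compound 3 is hydrogen in place of cyano on an aromatic carbon. The step that bears on it most directly is the exchange at the same place, a number 1.1 percentage points higher from compound 2 to compound 3 (within the scatter), which replaced one group by another on that ring without a change beyond the scatter; the chloro step a number 4.6 percentage points higher from compound 1 to compound 2 (within the scatter) was equally flat. With nothing in the series that moved the read-out, the expectation for removing the cyano is again no step beyond the scatter, in either direction.

Compound 4 is therefore estimated at 10%, with a range from 0% to 22%. The expected step is a number 2.7 percentage points lower from compound 3 to compound 4 (within the scatter).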

Compound 4, percent growth inhibition at one concentration: 14.9%
Compound 4: middle estimate off by 4.9 percentage points, on the low side, and the stated range covers the measured number.
By their numbers in this assay, from the lowest: compounds 1, 2, 3 and 4 (each within the scatter of the next).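

In this assay, the place para to a large group on the six-membered aromatic ring of carbon only has now been read with three different occupants: cyano, methylsulfonyl and hydrogen. Removing the substituent altogether gives a number 2.2 percentage points higher from compound 3 to compound 4 (within the scatter), and replacing methylsulfonyl with hydrogen gives a number 3.3 percentage points higher from compound 2 to compound 4 (within the scatter), so the 4-cyanophenyl to phenyl change supplies the unsubstituted reference that the earlier exchange between two substituents lacked, and neither substituent separates from that reference on this read-out. Nothing available bears on why this place stays flat on this read-out.

On these data alone, whether an amine, a carboxylic acid or a longer chain at this same place would produce a step beyond the scatter remains open, since the three occupants compared here do not show whether the read-out can respond to a change at this place at all. Also open, as far as these compounds go, is whether a change elsewhere on the shared core, such as an amine in place of the chloro group, would separate from these compounds at the one concentration tested.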